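From nitro to bromo in a small cytotoxicity series

The source may hold more compounds than are shown below. What is called first, only, known or untested is meant among the compounds shown, and "the series" means these compounds.

Of the compounds shown here, three have been measured in a functional assay on HepG2 cells (Homo sapiens) for cytotoxicity, read by MTT assay, with a stated time of 24 h (a higher number here means a weaker inhibitor, a lower number a stronger inhibitor), so far. Compound 1 (`CN1C/C(=C\c2ccncc2)C(=O)/C(=C/c2ccc(C#N)cc2)C1`) gives 13900 nM there, compound 2 (`O=C1/C(=C/c2cccnc2)CN(S(=O)(=O)c2ccc([N+](=O)[O-])cc2)C/C1=C\c1ccccc1F`) gives 12800 nM there, and compound 3 (`O=C1/C(=C/c2ccncc2)CN(S(=O)(=O)c2ccc([N+](=O)[O-])cc2)C/C1=C\c1ccccc1F`) gives 11300 nM as its result. These numbers lie within the usual scatter of one another, so compound 3 cannot be separated from the other two and no ranking can be read from them.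

Compound 4 (`O=C1/C(=C/c2ccncc2)CN(S(=O)(=O)c2ccc(Br)cc2)C/C1=C\c1ccccc1F`) differs from compound 3 in one place, where 4-nitrophenyl becomes 4-bromophenyl (bromo in place of nitro on an aromatic carbon) through bromo in place of nitro on an aromatic carbon. Among the compounds with values here, the only measured step between close relatives is a 1.1-fold lower number from compound 2 to compound 3 (0.05 log units; within the scatter) and it exchanges pyridin-3-yl for pyridin-4-yl while the nitro group stays in place. Compound 1 differs from compound 3 in several places, so it isolates no single change. Within the data shown here, no measured pair shows what replacing nitro does, which leaves no evidence for a shift in either direction.

The expectation therefore rests on compound 3 and its 11300 nM as the nearest measured relative. The estimated change is a 1.0-fold lower number from compound 3 to compound 4 (0.01 log units; within the scatter) and no step beyond the scatter is expected. Compound 4 is expected near 11000 nM in this assay with an estimated range from 5500 nM to 22000 nM for a single measurement.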

Compound 4, half-maximal inhibitory concentration: 9300 nM
The estimate for compound 4 lay 1.2-fold (0.07 log units) above the measured number; low and high end bracket the measured number.
By their numbers in this assay, from the lowest: compounds 4, 3, 2 and 1 (each within the scatter of the next).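

Moving from 4-nitrophenyl to 4-bromophenyl in this assay gives a 1.2-fold lower number from compound 3 to compound 4 (0.08 log units; within the scatter), and this is the first view of what happens on this aromatic carbon, para to a large group, as the earlier step changed only the pyridine ring. The exchange is not a minor one on paper: nitro brings 3 heavy atoms and 2 hydrogen-bond acceptors, while bromo brings 1 heavy atom and 0 hydrogen-bond acceptors, yet compound 3 and compound 4 cannot be told apart in this cytotoxicity read-out, so the nitro group is not needed for a value in this range. Nothing measured here explains why the two groups read alike.

Two groups at one position cannot show whether this carbon tolerates every change or whether another group, such as an amine, a carboxylic acid or a methoxy group, would produce a step beyond the scatter. On these data alone, it also remains open whether bromo in place of nitro would read the same with pyridin-3-yl in place of pyridin-4-yl on the shared core.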